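Swapping the Thiazoline Thioether for a Phenylpiperazine

This account rests on a few compounds, and the source may have more. Where it says the series, first, only, none or still open, it means among the compounds named here.

Compound 1 `Cn1c(-c2ccc(NC(=O)CSc3nc4ccccc4s3)cc2)nc(-c2ccccc2)c1-c1ccccc1`: 15.8 ug/mL
Compound 2 `Cn1nnnc1SCC(=O)Nc1ccc(-c2nc(-c3ccccc3)c(-c3ccccc3)n2C)cc1`: 4.5 ug/mL
Compound 3 `Cn1c(-c2ccc(NC(=O)CSC3=NCCS3)cc2)nc(-c2ccccc2)c1-c1ccccc1`: 26.7 ug/mL

In a functional assay on MCF7 cells (Homo sapiens) for cytotoxicity, read by MTT assay, with a stated time of 24 h (a higher number here means a weaker inhibitor, a lower number a stronger inhibitor), compound 3 gives the highest of the three numbers. Its nearest neighbour is compound 1, since the step of a 1.7-fold higher number from compound 1 to compound 3 (0.23 log units; within the scatter) lies within the scatter, whereas the step of a 5.9-fold higher number from compound 2 to compound 3 (0.77 log units; beyond the scatter) lies beyond it. Compound 4 `Cn1c(-c2ccc(NC(=O)CN3CCN(c4ccccc4)CC3)cc2)nc(-c2ccccc2)c1-c1ccccc1` is reached by a group of 12 heavy atoms (10 carbon, 2 nitrogen; one six-membered non-aromatic ring with 2 hetero atoms, one six-membered aromatic ring of carbon only) in place of a group of 6 heavy atoms (3 carbon, 1 nitrogen, 2 sulfur; one five-membered non-aromatic ring with 2 hetero atoms), on a saturated chain carbon bound to a carbonyl carbon. The measured steps all exchange one ring on the sulfur for another; the largest of them, a 3.5-fold lower number from compound 1 to compound 2 (0.55 log units; beyond the scatter), was still only modest. None of them removes the sulfur or brings in a piperazine, so they bear on this change only loosely, and the expected step is expected to be modest, more likely toward a lower number. The estimate for compound 4 is 12 ug/mL, with a range from 3 ug/mL to 45 ug/mL. The expected step is a 2.2-fold lower number from compound 3 to compound 4 (0.35 log units; beyond the scatter).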

Compound 4, half-maximal inhibitory concentration: 10.7 ug/mL
Compound 4: middle estimate off by 1.1-fold (0.05 log units), on the high side, within the range that was stated.
By their numbers in this assay, from the lowest: compound 2; then compounds 4, 1 and 3 (each within the scatter of the next, the first and the last beyond it).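

Putting 4-phenylpiperazin-1-yl on the saturated chain carbon bound to a carbonyl carbon shows that this place accepts a group without sulfur, since in this assay there is (  a 1.5-fold lower number from compound 1 to compound 4 (0.17 log units; within the scatter)  ) and a modest gain (a 2.5-fold lower number from compound 3 to compound 4 (0.40 log units; beyond the scatter)). The tetrazole thioether keeps the edge (a 2.4-fold higher number from compound 2 to compound 4 (0.38 log units; beyond the scatter)), so compound 2 and compound 3 lie on either side of compound 4. Nothing measured here explains these differences. Still open, going by these compounds, is what the phenyl contributes, and how a plain piperazine or a morpholine would compare at this carbon.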